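This account rests on a few compounds, and the source may have more. Where it says the series, first, only, none or still open, it means among the compounds named here.

In a functional assay on NCI-H460 cells (Homo sapiens) for antiproliferative activity, read by MTT assay, with a stated time of 48 h (on this read-out higher numbers stand for weaker inhibition and lower numbers for stronger inhibition), compound 1 `COc1cc(-c2cccc3nc(-c4ccccc4)oc23)cc(OC)c1OC` gives 6800 nM. Compound 2 `COc1ccc(-c2nc3cccc(-c4cc(OC)c(OC)c(OC)c4)c3o2)cc1OC` gives > 25000 nM, which is a limit of the assay and not a number. Compound 3 `COc1ccc(-c2nc3cccc(-c4cc(OC)c(OC)c(OC)c4)c3o2)cc1F` has fluoro in place of methoxy on an aromatic carbon, ortho to a methoxy group, taking 3,4-dimethoxyphenyl to 3-fluoro-4-methoxyphenyl: fluoro in place of methoxy on an aromatic carbon. Within the data shown here, the only measured step bearing on this is an at least 3.6-fold higher number from compound 1 to compound 2 (0.56 log units; beyond the scatter), so with one methoxy group gone, a modest shift to a lower number is expected in this assay. The expected shift is an at least 1.7-fold lower number from compound 2 to compound 3 (0.25 log units; that floor lies within the scatter). For compound 3, the estimated value is 14000 nM, within an expected range of 5000 nM to 25000 nM.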

Compound 3, half-maximal inhibitory concentration: 2800 nM
Estimate against measurement, compound 3: 5.0-fold (0.70 log units) above; measured number below the stated range.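

Putting fluoro in place of methoxy at this position, ortho to a methoxy group, restores activity in this assay, with an at least 8.9-fold lower number from compound 2 to compound 3 (0.95 log units; beyond the scatter) as the step. Compound 2 sits at a limit of the assay and not at a number, so that step is only a floor: the limit of > 25000 nM in this assay, at which 1 of the 3 values shown sits. The 3-fluoro-4-methoxyphenyl group also improves on plain phenyl, with a 2.4-fold lower number from compound 1 to compound 3 (0.39 log units; beyond the scatter) as the step, so among these compounds the outcome depends on which group stands at this position.

On these data alone, whether chloro, hydroxyl or an amine in place of the fluoro would give a similar number stays open. So does the true value of compound 2.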